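Swapping the Heteroaryl Ring on a Sulfur-Linked Side Chain

The source may hold more compounds than are shown below. What is called first, only, known or untested is meant among the compounds shown, and "the series" means these compounds.

Compound 1 `CCCCCCCN(CCCCC[S+]([O-])c1cc(-c2ccccc2)cnn1)C(=O)Nc1ccc(F)cc1F` gives 62% in an assay on microsomes from liver for inhibition of sterol O-acyltransferase 1 (Rattus norvegicus), tested at 50 ug/mL; a higher number here means more inhibition at the concentration tested (going by the name of the read-out), a lower number less inhibition.
Compound 2 `CCCCCCCN(CCCCC[S+]([O-])c1ccc(-c2ccccc2)nn1)C(=O)Nc1ccc(F)cc1F` gives 55% in this assay.
Compound 3 `CCCCCCCN(CCCCCS(=O)(=O)c1cc(-c2ccccc2)cnn1)C(=O)Nc1ccc(F)cc1F` gives 67% in this assay.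

Compound 1 and compound 2 share everything but the ring attached to the sulfur: a group of 12 heavy atoms (10 carbon, 2 nitrogen; one six-membered aromatic ring of carbon only, one six-membered aromatic ring with 2 hetero atoms) in place of a group of 12 heavy atoms (10 carbon, 2 nitrogen; one six-membered aromatic ring of carbon only, one six-membered aromatic ring with 2 hetero atoms), on a sulfur. The step that this change made is a number 7 percentage points lower from compound 1 to compound 2 (within the scatter).

Compound 3 carries a sulfonyl sulfur instead; how its core differs from that of compound 1 is not broken down here.

Compound 4 `CCCCCCCN(CCCCCS(=O)(=O)c1ccc(-c2ccccc2)nn1)C(=O)Nc1ccc(F)cc1F` is the counterpart of compound 2 on the sulfone: a group of 12 heavy atoms (10 carbon, 2 nitrogen; one six-membered aromatic ring of carbon only, one six-membered aromatic ring with 2 hetero atoms) in place of a group of 12 heavy atoms (10 carbon, 2 nitrogen; one six-membered aromatic ring of carbon only, one six-membered aromatic ring with 2 hetero atoms), on a sulfonyl sulfur. The place is not the same word for word as in the earlier pair. There the change sat on a sulfur whose other neighbours are oxygen and a saturated chain carbon; here it sits on a sulfonyl sulfur whose other neighbour is a saturated chain carbon. It is therefore the same kind of change, not the same change.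

For compound 4 a step of a number 7 percentage points lower from compound 3 to compound 4 (within the scatter) is expected, resting on compound 1 and the step of a number 7 percentage points lower from compound 1 to compound 2 (within the scatter). Compound 4 is thus estimated at 60%, from 46% to 72%.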

Compound 4, a percentage reported as inhibition, at one concentration (the size of the read-out at that concentration, not a potency): 43%
For compound 4 the middle estimate is 17 percentage points above the measured one, and the stated range ends above it.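

In this assay the ring change on the sulfonyl sulfur comes with a number 24 percentage points lower from compound 3 to compound 4 (beyond the scatter). The change therefore does not carry from one core to the other at a fixed size, and the step read on the first pair would not have given the size of the second: the same change on two cores in this assay, a number 7 percentage points lower (within the scatter) from compound 1 to compound 2 and a number 24 percentage points lower (beyond the scatter) from compound 3 to compound 4, 17 percentage points apart, beyond the scatter of two such steps. Among these compounds, this does not show why the two steps differ, and the comparison rests on only two pairs, each read at one concentration in one assay, so it gives no measure of potency and no rule for other cores.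

The compounds shown leave open how the same ring change would behave on a plain thioether sulfur, the third state of the sulfur alongside the two seen here. They also leave open whether the gap between the steps would persist with a shorter chain on the nitrogen, or with an amine or a carboxylic acid on the phenyl ring.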